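The source may report more compounds than this note shows. Statements on the series, on what has been measured and on what is new or still open speak of the compounds shown alone.

Measured compounds:
- compound 1 `N=C(N)N/N=C/c1c(-c2cccs2)nc2sccn12`: 10200 nM
- compound 2 `Cc1cc(-c2nc3sccn3c2/C=N/NC(=N)N)c(C)s1`: 17400 nM
- compound 3 `Cc1cc(-c2nc3n(c2/C=N/NC(=N)N)CCS3)c(C)s1`: 24000 nM

The read-out throughout is a functional assay on cells (Cancer cell lines, Homo sapiens) for inhibition; on this read-out lower numbers stand for stronger inhibition of growth and higher numbers for weaker inhibition of growth. Compound 1 and compound 2 share a core, and the change from compound 2 to compound 1 is thiophen-2-yl in place of 2,5-dimethylthiophen-3-yl on an aromatic carbon; it gave a 1.7-fold lower number from compound 2 to compound 1 (0.23 log units; within the scatter). Compound 3 carries a different core; how the core of compound 3 differs from that of compound 2 is not broken down here. Compound 3 and compound 2 sit within the scatter of each other, while the gap from compound 3 to compound 1 lies beyond it.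

Compound 4 `N=C(N)N/N=C/c1c(-c2cccs2)nc2n1CCS2` is not yet measured. It arises from compound 3 by thiophen-2-yl in place of 2,5-dimethylthiophen-3-yl on an aromatic carbon. This is the same kind of change as that from compound 2 to compound 1, though the place differs in that the aromatic carbon here is also two ring bonds from two ring atoms that each bear a fused ring. Because the earlier step was a 1.7-fold lower number from compound 2 to compound 1 (0.23 log units; within the scatter), a step of similar size, a 1.7-fold lower number from compound 3 to compound 4 (0.23 log units; within the scatter), is expected here, within the scatter. Compound 4 is therefore estimated at 14000 nM, likely between 7000 nM and 30000 nM.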

Compound 4, concentration for 50% growth inhibition: 39800 nM
Compound 4: middle estimate off by 2.8-fold (0.45 log units), on the low side, outside the stated range (above it).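

In this assay, thiophen-2-yl in place of 2,5-dimethylthiophen-3-yl on an aromatic carbon gave a 1.7-fold higher number from compound 3 to compound 4 (0.22 log units; within the scatter). Set beside the earlier step, the same change did not give the same result on the two cores: the same change on two cores in this assay, a 1.7-fold lower number (0.23 log units; within the scatter) from compound 2 to compound 1 and a 1.7-fold higher number (0.22 log units; within the scatter) from compound 3 to compound 4, 2.8-fold (0.45 log units) apart, beyond the scatter of two such steps Each step on its own stays within the scatter, so the comparison shows only that the step cannot be assumed to carry from one core to the other; it does not show that the change strengthens or weakens growth inhibition on either core, and one pair per core gives no explanation for the gap.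

The compounds shown place only thiophen-2-yl and 2,5-dimethylthiophen-3-yl on this aromatic carbon, so it remains open whether the gap between the cores is specific to this pair of groups. Also open, as far as these compounds go, is how an amine or a carboxylic acid at the same place would behave on each core.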